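A few compounds are considered here, and "the series" means these few. Any claim that something is new, unique, unknown or untested is made for them only; others in the source may bear on it.

Three closely related compounds have been examined in a functional assay on HeLa cells (Homo sapiens) for cytotoxicity, read by MTT assay, with a stated time of 24 h; a lower number here means a stronger inhibitor, a higher number a weaker inhibitor. Compound 1, with the structure `Cc1cc(O)c(C(=O)/C=C/c2ccc(F)cc2)c(-c2ccccc2)c1C(=O)/C=C/c1ccc(F)cc1`, gives 30000 nM in this assay. Compound 2, with the structure `Cc1cc(O)c(C(=O)/C=C/c2cccc(Cl)c2)c(-c2ccccc2)c1C(=O)/C=C/c1cccc(Cl)c1`, gives 22000 nM in this assay. These two numbers lie within the usual scatter of each other, so nothing separates them. Compound 3, with the structure `Cc1cc(O)c(C(=O)/C=C/c2ccc3ccccc3c2)c(-c2ccccc2)c1C(=O)/C=C/c1ccc2ccccc2c1`, was reported as "not active" (no number reported) in this assay, and no number was recorded for it. Compound 3 therefore stands at the weak end of what has been seen: where compound 1 and compound 2 at least reached a measurable value, compound 3 did not.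

Compound 4, with the structure `Cc1cc(O)c(C(=O)/C=C/c2ccc3ccccc3c2)c(-c2ccc(Cl)cc2)c1C(=O)/C=C/c1ccc2ccccc2c1`, has not yet been measured in this assay. It differs from compound 3 in one place: chloro in place of hydrogen on an aromatic carbon. Nothing in the data shows what a single chloro in place of hydrogen does on this shared core, so the size of the step cannot be read from a measured pair. The expectation rests on compound 3 alone, which gave no measurable number, and on compound 1 and compound 2, which were weak. Compound 4 is therefore expected to be weak as well, with an estimated value of 40000 nM, somewhere between 15000 nM and 120000 nM, and a real chance that only a limit is reported.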

Compound 4, half-maximal inhibitory concentration: "not active" (no number reported)
Compound 4: no number reported, so the estimate cannot be set against anything.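

In this assay neither compound 3 nor compound 4 has a number, so no step can be read for the change from phenyl to 4-chlorophenyl. Nothing measured here offers an explanation for this result. Going by these compounds, what a chloro in place of hydrogen does to activity on this shared core remains open.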